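The compounds below may be only part of what the source reports. "The series", "measured", "known", "first", "only" and "open" are said of these compounds alone.

Measured compounds in a functional assay, with a stated time of 6 min; on this read-out lower numbers stand for stronger inhibition and higher numbers for weaker inhibition:
- compound 1, `Fc1ccccc1NCn1nc(-c2ccc3c(c2)OCCO3)oc1=S`, gives 6390 nM
- compound 2, `Fc1ccc(NCn2nc(-c3ccc4c(c3)OCCO4)oc2=S)cc1`, gives 6480 nM
- compound 3, `S=c1oc(-c2ccc3c(c2)OCCO3)nn1CNc1cccc(Cl)c1`, gives 6220 nM

All three compounds share the same core and differ only in the halogen-bearing aryl group on the amine nitrogen. Compound 1 gives a number that cannot be separated from the other two: the steps of a 1.0-fold higher number from compound 1 to compound 2 (0.01 log units; within the scatter) and a 1.0-fold lower number from compound 1 to compound 3 (0.01 log units; within the scatter) are both within the scatter, as is the step of a 1.0-fold lower number from compound 2 to compound 3 (0.02 log units; within the scatter). Moving the fluorine from one position to another, or swapping fluorine for chlorine at a different position, leaves this assay unmoved.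

Compound 4, `S=c1oc(-c2ccc3c(c2)OCCO3)nn1CNc1cccc(Br)c1`, is the next member of this set. The change from compound 1 is 3-bromophenyl in place of 2-fluorophenyl on an amine nitrogen. Among the measured compounds shown here, the closest precedent is compound 3, which carries 3-chlorophenyl, and its step of a 1.0-fold lower number from compound 1 to compound 3 (0.01 log units; within the scatter) was flat; the step of a 1.0-fold higher number from compound 1 to compound 2 (0.01 log units; within the scatter) was flat too. For the measured compounds named here, no measured step on this series has moved the number beyond the scatter, so the expected step of a 1.0-fold lower number from compound 1 to compound 4 (0.01 log units; within the scatter) is none beyond the scatter. Compound 4 is therefore estimated at 6300 nM, with a range from 3200 nM to 12500 nM.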

Compound 4, half-maximal inhibitory concentration: 10800 nM
Beside the measured number, compound 4's estimate is 1.7-fold (0.23 log units) below it; low and high end bracket the measured number.
By their numbers in this assay, from the lowest: compounds 3, 1, 2 and 4 (each within the scatter of the next).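

In this assay the 3-bromophenyl group on the amine nitrogen cannot be told apart from any of the three earlier aryl groups: the steps of a 1.7-fold higher number from compound 1 to compound 4 (0.23 log units; within the scatter) and a 1.7-fold higher number from compound 2 to compound 4 (0.22 log units; within the scatter) and a 1.7-fold higher number from compound 3 to compound 4 (0.24 log units; within the scatter) all stay inside the usual spread of repeat measurements. Among the compounds shown here, the last of these is the most direct comparison, with bromo in place of chloro on an aromatic carbon as the only change, and it extends the flat picture from fluorine and chlorine to bromine, even though these steps are wider than the earlier ones. Nothing measured alongside these compounds offers an explanation for the numbers.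

On these data alone, all four compounds carry a single halogen on the phenyl ring, so it remains open whether a methoxy group, a nitrile or a carboxylic acid on that ring would also leave the number unmoved. Also open, as far as these compounds go, is whether a pyridine ring in place of the phenyl ring, or a longer chain between the amine nitrogen and the shared core, would shift the number beyond the scatter.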